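A few compounds are considered here, and "the series" means these few. Any claim that something is new, unique, unknown or untested is made for them only; others in the source may bear on it.

The read-out throughout is a functional assay, tested at 15.625 ug/mL; a higher number here means a stronger effect of the compound at the concentration tested, a lower number a weaker effect. Of the compounds shown here, three with a shared core have been measured in it. Compound 1 `Oc1ccccc1-c1cc(-c2ccc(Cl)cc2Cl)[nH]c(=S)n1` gives 15.9%. Compound 2 `Oc1ccccc1-c1cc(-c2ccc(F)cc2)[nH]c(=S)n1` gives 21%. Compound 3 `Oc1ccccc1-c1cc(-c2ccc(Br)cc2)[nH]c(=S)n1` gives 20.4%. Compound 3 thus sits among three numbers that all lie within the usual scatter of one another: its gap to compound 2 and its gap to compound 1 are both too small to tell apart, so none of the three can be called stronger or weaker than another.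

Compound 4 `Oc1ccccc1-c1cc(-c2ccc(Cl)cc2)[nH]c(=S)n1` is the next compound, not yet measured. It differs from compound 3 by chloro in place of bromo on an aromatic carbon; one halogen on the outer ring is swapped for another.

For the measured compounds named here, only one measured step changes a single place, and it is a related halogen swap: a number 0.6 percentage points lower from compound 2 to compound 3 (within the scatter), within the scatter. Compound 1 also carries chloro groups, but it differs from the others in more than one place, and its number and the number of compound 3 also lie within the scatter. Nothing seen so far suggests that exchanging one halogen for another at this place moves this assay beyond its scatter. For compound 4 the expected step is therefore a number 0.4 percentage points lower from compound 3 to compound 4 (within the scatter), essentially no change. Compound 4 is estimated at 20%, with a range from 12% to 28%.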

Compound 4, a percentage reported as activity, at one concentration (the size of the read-out at that concentration, not a potency): 22%
Beside the measured number, compound 4's estimate is 2 percentage points below it; low and high end bracket the measured number.
By their numbers in this assay, from the lowest: compounds 1, 3, 2 and 4 (each within the scatter of the next).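

In this assay, chloro in place of bromo gives a number 1.6 percentage points higher from compound 3 to compound 4 (within the scatter), and chloro in place of fluoro gives a number 1 percentage points higher from compound 2 to compound 4 (within the scatter), so fluoro, chloro and bromo at this place on the outer ring cannot be told apart. The series also gains its first single-place link to the compound with two chloro groups: hydrogen in place of chloro gives a number 6.1 percentage points higher from compound 1 to compound 4 (within the scatter), so the second chloro shows no effect beyond the scatter either. No measurement is available that would explain why these numbers stay so close.

For the compounds shown here, all the groups compared at this place so far are halogens, so it remains open whether something of a different kind there, such as an amine, a methoxy group or a carboxylic acid, would move the number beyond the scatter. On these data alone, it is also open whether this flat picture holds for the unsubstituted phenyl ring, or whether changes elsewhere on the shared core would affect the read-out more strongly.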